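The compounds below may be only part of what the source reports. "The series", "measured", "known", "first", "only" and "open" are said of these compounds alone.

Measured in a functional assay on MCF7 cells (Homo sapiens) for antiproliferative activity, read by MTT assay, with stated times of 24 h and 72 h; on this read-out higher numbers stand for weaker inhibition and lower numbers for stronger inhibition:
- Compound 1 `COc1cc(N2C(=O)[C@@H](Oc3ccccc3)[C@H]2c2cccc([N+](=O)[O-])c2)cc(OC)c1OC`: 30000 nM
- Compound 2 `COc1cc(N2C(=O)[C@@H](Oc3ccccc3)[C@H]2c2ccc([N+](=O)[O-])cc2)cc(OC)c1OC`: 63000 nM

Among the compounds with values here, of these two numbers, the one for compound 2 is the higher, which makes it the weaker inhibitor of the pair. Compound 3 `COc1cc(N2C(=O)[C@@H](Oc3ccccc3)[C@H]2c2ccc(SC)cc2)cc(OC)c1OC` keeps the shared core but has methylsulfanyl in place of nitro on an aromatic carbon, para to a large group: methylsulfanyl in place of nitro on an aromatic carbon.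

Within the data shown here, only one measured step bears on this change: a 2.1-fold higher number from compound 1 to compound 2 (0.32 log units; beyond the scatter). That step is modest, though beyond the scatter, and it only moves the nitro group to another position. Among the measured compounds shown here, no measured compound lacks the nitro group, so the effect of replacing it remains untested and any forecast is loose. Since compound 2 sits at 63000 nM, the top of the measured numbers, a shift toward stronger inhibition in this assay is expected, probably larger than the measured step. The estimate corresponds to an expected 11-fold lower number from compound 2 to compound 3 (1.02 log units; beyond the scatter). For compound 3 the expected value is 6000 nM, with an estimated range from 600 nM to 50000 nM.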

Compound 3, half-maximal inhibitory concentration: 7700 nM
For compound 3 the middle estimate is 1.3-fold (0.11 log units) below the measured one, within the range that was stated.
By their numbers in this assay, from the lowest: compound 3; then compound 1; then compound 2.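

Compounds 1 and 2 differed only in where the nitro group sat, whereas compound 3 shows what happens when that group is replaced: in this assay, methylsulfanyl in its place gives an 8.2-fold lower number from compound 2 to compound 3 (0.91 log units; beyond the scatter), a larger step than moving the nitro group, which gave a 2.1-fold higher number from compound 1 to compound 2 (0.32 log units; beyond the scatter). The change also takes the series past the better of the two nitro compounds, with a 3.9-fold lower number from compound 1 to compound 3 (0.59 log units; beyond the scatter), although this comparison changes both the group and its position on the ring, so it cannot separate the two effects. Compound 3 is therefore the strongest inhibitor of the three, which shows that a nitro group is not needed for activity on this ring, but nothing available here explains why the swap lowers the number.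

Methylsulfanyl is the only replacement shown, so it remains open whether an amine, a carboxylic acid or a longer chain such as ethylsulfanyl in the same place would lower the number further or raise it again. Going by these compounds, it is also open whether methylsulfanyl would do better or worse at the position the nitro group occupies in compound 1.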